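The source may report more compounds than this note shows. Statements on the series, on what has been measured and on what is new or still open speak of the compounds shown alone.

The study tests how well a small set of acids block a functional assay on CHO-K1 cells for antagonist activity at prostaglandin E2 receptor EP1 subtype (Homo sapiens), read by FLIPR; on this read-out lower numbers stand for stronger inhibition and higher numbers for weaker inhibition. Compound 1 `O=C(O)c1nn(Cc2cc(Br)ccc2OCc2ccccc2)cc1C(F)(F)F` carries a trifluoromethyl group on the shared core and an unsubstituted benzyl ether. For compound 1 this assay reports only a limit, < 2000 nM, and not a number. Going by the values given here, that leaves compound 2 `Cc1cc(C(=O)O)nn1Cc1cc(Br)ccc1OCc1ccc(Cl)cc1`, with a methyl group on the core and a 4-chlorobenzyl ether, as the only compound with a measured number: in this assay compound 2 gives 8.71 nM. Among the compounds with values here, because the other value is a limit (the limit of < 2000 nM in this assay, at which 1 of the 2 values shown sits), no step between measured compounds can be sized, and compound 2 stands alone as the reference point.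

Compound 3 `COc1ccccc1COc1ccc(Br)cc1Cn1nc(C(=O)O)cc1C` keeps everything of compound 2 except the aryl end of the ether: 2-methoxyphenyl in place of 4-chlorophenyl on a saturated chain carbon bound to an oxygen on an aromatic ring. Within the data shown here, no measured pair shows what such a swap does here, so the expectation rests on compound 2 alone. The move from compound 2 to compound 3 is expected to cost some potency, with a step of a 3.4-fold higher number from compound 2 to compound 3 (0.54 log units; beyond the scatter), near the edge of the usual scatter or a little beyond it. Compound 3 is therefore estimated at 30 nM in this assay, with a likely range from 8 nM to 150 nM.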

Compound 3, inhibition constant: 69.2 nM
Estimate against measurement, compound 3: 2.3-fold (0.36 log units) below, and the stated range covers the measured number.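

Going by these compounds alone, the swap gives the first measured step at this position: in this assay, 2-methoxyphenyl in place of 4-chlorophenyl on a saturated chain carbon bound to an oxygen on an aromatic ring gives a 7.9-fold higher number from compound 2 to compound 3 (0.90 log units; beyond the scatter). This shows that the aryl end of the ether affects the read-out, which compound 2 alone could not show. The step is modest, however, and compound 3 still gives a measured number of 69.2 nM, so this position accepts a change in both the kind of group on the aromatic ring and its location, with some loss of potency, and no measurement shown here explains the size of the step.

Within the data shown here, the single swap leaves open whether the loss comes from losing the chlorine, gaining the methoxy group, or the different location of the group, and a 2-chlorophenyl, a 4-methoxyphenyl or a plain phenyl group on the same methyl-bearing core would help separate these. It also leaves open how the potency would respond to a larger change at this end, such as a pyridine ring in place of the phenyl ring or a longer chain between the ether oxygen and the ring.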